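The source may report more compounds than this note shows. Statements on the series, on what has been measured and on what is new or still open speak of the compounds shown alone.

Measured compounds:
Compound 1, `Cc1cccc(C)c1NC(=O)CSc1nnc(-c2ccoc2C)n1Cc1ccco1`, gives > 15800 nM in a functional assay on CHO cells for antagonist activity at Orexin receptor type 2 (Homo sapiens), read by FLIPR and calcium flux; on this read-out higher numbers stand for weaker inhibition and lower numbers for stronger inhibition; this is a limit of the assay, not a number.
Compound 2, `Cc1cccc(NC(=O)CSc2nnc(-c3ccoc3C)n2Cc2ccco2)c1C`, gives > 15800 nM in this assay; this too is a limit.
Compound 3, `COc1ccc(C)cc1NC(=O)CSc1nnc(-c2ccoc2C)n1Cc1ccco1`, gives 15.9 nM in this assay.

Compound 3 is the only one of the three with a measured number; the other two sit at the limit of > 15800 nM in this assay, at which 2 of the 3 values shown sit. The step of an at least 990-fold lower number from compound 1 to compound 3 (2.99 log units; beyond the scatter) and the step of an at least 990-fold lower number from compound 2 to compound 3 (2.99 log units; beyond the scatter) are both large, so the group on the amide-type nitrogen clearly matters. The step that the two limits leave unreadable from compound 1 to compound 2 cannot be read, since both ends are limits.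

Compound 4, `Cc1occc1-c1nnc(SCC(=O)Nc2ccc(F)c(Cl)c2)n1Cc1ccco1`, differs from compound 3 in one place: 3-chloro-4-fluorophenyl in place of 2-methoxy-5-methylphenyl on an amide-type nitrogen. The methoxy group that compound 3 carries is gone, and two halogens come in. The measured steps show that exchanging one aryl group for another on this nitrogen can move the number very far, but none of them involves a halogenated ring, so the direction is uncertain. A step of a 63-fold higher number from compound 3 to compound 4 (1.80 log units; beyond the scatter) is expected, with a real chance that only a limit is reported. Compound 4 is estimated at 1000 nM in this assay, between 100 nM and 15800 nM.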

Compound 4, inhibition constant: 39.8 nM
Compound 4: the middle estimate sits 25-fold (1.40 log units) above what was measured; the measured number lies below the stated range.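

Compound 4 shows that a low number at this position does not depend on the methoxy group of compound 3: the step is a 2.5-fold higher number from compound 3 to compound 4 (0.40 log units; beyond the scatter), a modest change, even though a ring with two halogens and no hydrogen-bond acceptor takes the place of the 2-methoxy-5-methylphenyl group. It also shows that the sharp loss seen with the two dimethylphenyl groups does not follow from every change away from 2-methoxy-5-methylphenyl, since 3-chloro-4-fluorophenyl stands clearly apart from both, with an at least 390-fold lower number from compound 2 to compound 4 (2.59 log units; beyond the scatter) and an at least 390-fold lower number from compound 1 to compound 4 (2.59 log units; beyond the scatter). The values of compound 1 and compound 2 are limits of the assay, not numbers, so these two steps have a minimum size only: the limit of > 15800 nM in this assay, at which 2 of the 4 values shown sit.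

The compounds shown leave open whether chlorine or fluorine alone on the phenyl ring would give a similar number, as the two appear here only together. They also leave open how an amine, a carboxylic acid or a nitrile on that ring would change the number in this assay.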